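The compounds below may be only part of what the source reports. "The series", "measured", "known", "first", "only" and "open" are said of these compounds alone.

In an ADME assay on KB cells (Homo sapiens) for cytotoxicity, read by MTT assay, with a stated time of 72 h (on this read-out higher numbers stand for lower toxicity in this test and lower numbers for higher toxicity in this test), compound 1 `COc1ccnc(-c2nc(Nc3ccc(Cl)cn3)sc2Cl)c1` gives 15000 nM, compound 2 `Clc1ccc(Nc2nc(-c3cccnn3)cs2)nc1` gives 10300 nM and compound 3 `Clc1ccc(Nc2nc(-c3cccnn3)c(Cl)s2)nc1` gives 28100 nM. Compound 3 thus lies within the scatter of compound 1 but clearly apart from compound 2. Compound 4 `Clc1ccc(Nc2nc(-c3cnccn3)c(Cl)s2)nc1` has the same atoms as compound 3, joined differently: pyrazin-2-yl in place of pyridazin-3-yl on an aromatic carbon. Among the measured compounds shown here, the only measured single change, a 2.7-fold higher number from compound 2 to compound 3 (0.44 log units; beyond the scatter), is modest and concerns a chloro group, so it does not speak directly to this swap. Compound 1, with a different group in that place, still gives 15000 nM. No shift beyond the scatter is therefore expected in this assay. The estimated step, a 1.3-fold lower number from compound 3 to compound 4 (0.11 log units; within the scatter), stays small. Compound 4 is expected near 22000 nM, with an estimated range from 9000 nM to 50000 nM.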

Compound 4, half-maximal cytotoxic concentration: 3170 nM
For compound 4 the middle estimate is 6.9-fold (0.84 log units) above the measured one, outside the stated range (below it).
By their numbers in this assay, from the lowest: compound 4; then compounds 2, 1 and 3 (each within the scatter of the next, the first and the last beyond it).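

In this assay, putting pyrazin-2-yl in place of pyridazin-3-yl gives an 8.9-fold lower number from compound 3 to compound 4 (0.95 log units; beyond the scatter), so toxicity in this test rises. The two groups have the same atoms and the same counts of donors and acceptors, so this place on the shared core responds to how a ring is joined, not only to what it contains. Nothing measured here explains the shift. Still open, as far as these compounds go, is what an amine or a carboxylic acid on the pyrazin-2-yl ring would do, and whether the same swap has a similar effect without the neighbouring chloro group.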